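This account rests on a few compounds, and the source may have more. Where it says the series, first, only, none or still open, it means among the compounds named here.

Working notes on the series. Compound 1 `CC1CC(C(=O)N2CCc3nc(C#Cc4ccccc4)sc3C2)C1` is the reference point: in an assay on HEK293 cells for positive allosteric modulation of metabotropic glutamate receptor 5 (Homo sapiens), read by FLIPR, with a stated time of 1 h (on this read-out lower numbers stand for an effect already at smaller amounts and higher numbers for an effect only at larger amounts of compound), compound 1 gives 81 nM. Compound 2 `COC1CC(C(=O)N2CCc3nc(C#Cc4ccccc4)sc3C2)C1` gives 640 nM in this assay, and the step of a 7.9-fold higher number from compound 1 to compound 2 (0.90 log units; beyond the scatter) is the only modest movement seen so far. Compound 3 `CC1CCCC(C(=O)N2CCc3nc(C#Cc4ccccc4)sc3C2)C1` gives 100 nM in this assay; this puts compound 3 second highest of the three numbers, with compound 1 nearest (a 1.2-fold higher number from compound 1 to compound 3 (0.09 log units; within the scatter)) and compound 2 furthest (a 6.4-fold lower number from compound 2 to compound 3 (0.81 log units; beyond the scatter)).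

Compound 4 `O=C(N1CCC(F)CC1)N1CCc2nc(C#Cc3ccccc3)sc2C1` is the next change from compound 3: 4-fluoropiperidin-1-yl in place of 3-methylcyclohexyl on a carbonyl carbon. Of the measured steps, only a 7.9-fold higher number from compound 1 to compound 2 (0.90 log units; beyond the scatter) involves a hetero atom entering where carbon stood, and it raised the number modestly, whereas the ring-size change a 1.2-fold higher number from compound 1 to compound 3 (0.09 log units; within the scatter) stayed within the scatter. Within the data shown here, for compound 4 a ring of carbon only is exchanged for a six-membered ring with one hetero atom plus a fluorine, which has no direct precedent here; a rise of a similar modest size is therefore expected rather than a shift as large as that to compound 2. Compound 4 is expected at 300 nM, with a range of 100 nM to 900 nM. The expected step is a 3.0-fold higher number from compound 3 to compound 4 (0.48 log units; beyond the scatter).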

Compound 4, half-maximal effective concentration: 74 nM
The estimate for compound 4 lay 4.1-fold (0.61 log units) above the measured number; the whole stated range lies above it.
By their numbers in this assay, from the lowest: compounds 4, 1 and 3 (each within the scatter of the next); then compound 2.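

At this position on the carbonyl carbon, a ring nitrogen and a fluorine can enter in place of an all-carbon ring with no movement beyond the scatter (a 1.4-fold lower number from compound 3 to compound 4 (0.13 log units; within the scatter)), and the same holds against the smaller carbon ring of the reference (a 1.1-fold lower number from compound 1 to compound 4 (0.04 log units; within the scatter)). A hetero atom in the group on this carbonyl carbon therefore does not by itself go with a higher number: the rise seen with the methoxy group of compound 2 does not appear here, and compound 2 stays apart from the new compound (an 8.6-fold lower number from compound 2 to compound 4 (0.94 log units; beyond the scatter)). No data are at hand to explain why these two hetero-atom groups part ways.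

The 4-fluoropiperidin-1-yl group brings the ring nitrogen and the fluorine in a single step, and the compounds shown do not separate the two, so a plain piperidin-1-yl or a morpholin-4-yl group on the same carbonyl carbon would be the direct comparison. Also open, from the compounds shown here alone, is whether the higher number of compound 2 belongs to the methoxy group in particular, a question that a hydroxy or an ethoxy group on the cyclobutyl ring would address.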